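The compounds below may be only part of what the source reports. "The series", "measured", "known", "first", "only" and "open" are said of these compounds alone.

Measured so far:
compound 1 `C[C@H]([C@H](C(=O)Nc1cccc(CC2(C(=O)O)CC2)c1)c1ccc(Cl)cc1)C(F)(F)F` gives 4% in an assay on CHO cells for activation of Guanylate cyclase soluble subunit alpha-1 (Rattus norvegicus), read by luminescence and cGMP accumulation, with a stated time of 6 min; a higher number here means a larger maximal response, a lower number a smaller maximal response
compound 2 `Cc1ccc(CC2(C(=O)O)CC2)cc1NC(=O)[C@H](c1ccc(Cl)cc1)[C@@H](C)C(F)(F)F` gives 44% in this assay

Compound 2 stands highest of the two numbers, its nearest neighbour being compound 1. Compound 3 `C[C@H]([C@H](C(=O)Nc1cc(CC2(C(=O)O)CC2)ccc1F)c1ccc(Cl)cc1)C(F)(F)F` differs from compound 2 by fluoro in place of methyl on an aromatic carbon. Among the measured compounds shown here, the one step that bears on this carbon is a number 40 percentage points higher from compound 1 to compound 2 (beyond the scatter), a large gain when methyl entered. Whether fluoro holds that gain is not known from the data; as the aromatic carbon is shown to matter, a partial loss is expected, so a number 19 percentage points lower from compound 2 to compound 3 (beyond the scatter). Compound 3 is estimated at 25%, range 5% to 50%.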

Compound 3, largest response reached (reported as efficacy), in percent of the reference or control that the assay uses: 34%
Estimate against measurement, compound 3: 9 percentage points below; the range from low to high includes it.
By their numbers in this assay, from the lowest: compound 1; then compounds 3 and 2 (each within the scatter of the next).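

In this assay the aromatic carbon ortho to a large group accepts fluoro as readily as methyl, with a number 10 percentage points lower from compound 2 to compound 3 (within the scatter) on this exchange, so the response does not depend on methyl itself. Against hydrogen at this carbon, fluoro gives a number 30 percentage points higher from compound 1 to compound 3 (beyond the scatter) and thus joins methyl in standing clear of the unsubstituted compound. Nothing on hand accounts for this.

Still open, going by these compounds, is whether a larger group at this carbon, such as methoxy or ethyl, keeps the response. A hydroxyl or an amine here would show whether other kinds of group are accepted.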